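A few compounds are considered here, and "the series" means these few. Any claim that something is new, unique, unknown or untested is made for them only; others in the source may bear on it.

Measured compounds in a physicochemical assay for lipophilicity, read by HPLC, in phosphate buffer, measured as chromatographic lipophilicity, at pH 7.4; a lower number here means a more polar compound, a higher number a more lipophilic compound:
compound 1 `COc1ccc2nc(C(F)(F)F)cc(OCC(=O)Nc3cc(C)cc(C)c3)c2c1` gives 7.02
compound 2 `COc1ccc2nc(C)cc(OC(C)(C)C(=O)Nc3cc(C)cc(C)c3)c2c1` gives 6.37
compound 3 `COc1ccc2nc(C)cc(OCC(=O)NCc3cc(C)cc(C)c3)c2c1` gives 5.25

Compound 3 stands lowest of the three numbers; compound 2 lies higher by a margin beyond the scatter, and compound 1 lies higher still, also beyond the scatter. Compound 4 `COc1ccc2nc(C)cc(OCC(=O)Nc3ccc(Cl)cc3)c2c1` differs from compound 3 in one place: 4-chlorophenyl in place of 3,5-dimethylbenzyl on an amide-type nitrogen. Among the compounds with values here, no pair of measured compounds differs in one place only, so the size of a change of this kind has not been seen directly. The expected step of a number 0.25 log units higher from compound 3 to compound 4 (within the scatter) in this assay is a modest upward shift, around the edge of the usual scatter rather than far beyond it. Compound 4 is expected to give about 5.5, within a range from 4.9 to 6.1.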

Compound 4, distribution coefficient: 5.15
Compound 4: the middle estimate sits 0.35 log units above what was measured; measured number inside the range.
By their numbers in this assay, from the lowest: compounds 4 and 3 (each within the scatter of the next); then compound 2; then compound 1.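

Putting 4-chlorophenyl in place of 3,5-dimethylbenzyl on the amide-type nitrogen gives a number 0.10 log units lower from compound 3 to compound 4 (within the scatter) in this assay, the first one-place step read in the series. At this position, then, a group of 7 heavy atoms including chlorine and a group of 9 carbon atoms are not told apart by this read-out. Nothing at hand gives a reason for this result. 

This single step does not separate the exchange of ring substituents from the exchange of benzyl for phenyl. Going by these compounds, how an amine or a carboxylic acid on this nitrogen would read remains open.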